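The source may hold more compounds than are shown below. What is called first, only, known or untested is meant among the compounds shown, and "the series" means these compounds.

Of the compounds shown here, three sharing one core have been measured in a functional assay on cells (Cancer cell lines, Homo sapiens) for cytotoxicity, read by sulforhodamine B assay, with a stated time of 48 h; a lower number here means a stronger inhibitor of growth, a higher number a weaker inhibitor of growth. Compound 1 `COc1ccc(C2CC(c3ccccc3)=NN2C2=NC(=O)/C(=C3\C(=O)Nc4ccccc43)S2)cc1` gives 4390 nM. Compound 2 `COc1ccc(C2=NN(C3=NC(=O)/C(=C4\C(=O)Nc5ccccc54)S3)C(c3ccc(OC)cc3)C2)cc1` gives 100000 nM, and compound 3 `O=C1N=C(N2N=C(c3ccccc3)CC2c2ccc(Cl)cc2)S/C1=C1/C(=O)Nc2ccccc21` gives 390 nM. Among these three numbers compound 3 stands lowest, so it is the strongest growth inhibitor of the group. Methoxy in place of hydrogen on an aromatic carbon gave a 23-fold higher number from compound 1 to compound 2 (1.36 log units; beyond the scatter), while chloro in place of methoxy on an aromatic carbon gave an 11-fold lower number from compound 1 to compound 3 (1.05 log units; beyond the scatter).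

Compound 4 `COc1ccc(C2=NN(C3=NC(=O)/C(=C4\C(=O)Nc5ccccc54)S3)C(c3ccc(Cl)cc3)C2)cc1` has not yet been measured. It differs from compound 3 by methoxy in place of hydrogen on an aromatic carbon. The first of the two measured steps bears directly on this change, since it added the same methoxy to the same phenyl on the shared core and made the number much higher. A step of the same kind, though possibly somewhat smaller, is therefore expected here in this assay: a 13-fold higher number from compound 3 to compound 4 (1.11 log units; beyond the scatter). For compound 4 the expected value is 5000 nM, with a likely range from 1500 nM to 20000 nM.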

Compound 4, concentration for total growth inhibition: 100000 nM
The estimate for compound 4 lay 20-fold (1.30 log units) below the measured number; measured number outside the range, above it.
By their numbers in this assay, from the lowest: compound 3; then compound 1; then compounds 2 and 4 (each within the scatter of the next).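

In this assay, methoxy in place of hydrogen at this position raises the number on both cores, so the direction holds, but the size of the rise depends on the rest of the compound, with a 260-fold higher number from compound 3 to compound 4 (2.41 log units; beyond the scatter) for the chloro pair: the same change on two cores in this assay, a 23-fold higher number (1.36 log units; beyond the scatter) from compound 1 to compound 2 and a 260-fold higher number (2.41 log units; beyond the scatter) from compound 3 to compound 4, 11-fold (1.05 log units) apart, beyond the scatter of two such steps

Chloro in place of methoxy, which lowered the number on the core of compound 1, gives no change at the digits printed from compound 2 to compound 4 (within the scatter) once the 4-methoxyphenyl is in place: the same change on two cores in this assay, an 11-fold lower number (1.05 log units; beyond the scatter) from compound 1 to compound 3 and no change at the digits printed (within the scatter) from compound 2 to compound 4, 11-fold (1.05 log units) apart, beyond the scatter of two such steps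

The two changes therefore do not simply add up, since the chloro gain seen with the plain phenyl disappears in the presence of this methoxy.

On these data alone, whether fluoro, hydroxyl or an amine at this position would keep the number as low as in compound 3 or raise it as methoxy does remains open. What lies behind the rise also stays unknown.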